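The source may hold more compounds than are shown below. What is called first, only, known or untested is meant among the compounds shown, and "the series" means these compounds.

Measured in a functional assay on A549 cells (Homo sapiens) for antiproliferative activity, read by MTT assay, with a stated time of 48 h; a lower number here means a stronger inhibitor, a higher number a weaker inhibitor:
compound 1 `Oc1ccc2ccccc2c1C(Nc1nc2ccccc2s1)c1cn(-c2ccccc2)nc1-c1ccc(I)cc1`: 23100 nM
compound 2 `Oc1ccc2ccccc2c1C(Nc1nc2ccc(Cl)cc2s1)c1cn(-c2ccccc2)nc1-c1ccccc1`: 51100 nM

Of the two, compound 2 at 51100 nM has the higher number and is the weaker inhibitor, and its gap to compound 1 lies beyond the scatter. Compound 3 `Oc1ccc2ccccc2c1C(Nc1nc2ccc(Cl)cc2s1)c1cn(-c2ccccc2)nc1-c1ccc(I)cc1` departs from compound 2 in one place: phenyl becomes 4-iodophenyl, with iodo in place of hydrogen on an aromatic carbon, para to a large group (iodo in place of hydrogen on an aromatic carbon). Among the compounds with values here, no measured pair isolates this change, since compound 1 and compound 2 differ in more than one place. Compound 1 does carry the 4-iodophenyl group and gives 23100 nM, which offers only a weak hint. A modest move to a lower number in this assay is therefore expected, although a step within the scatter would be no surprise. The expected change is a 1.9-fold lower number from compound 2 to compound 3 (0.28 log units; within the scatter). For compound 3 the estimated value is 27000 nM, with an expected range of 12000 nM to 60000 nM.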

Compound 3, half-maximal inhibitory concentration: 29000 nM
Estimate against measurement, compound 3: 1.1-fold (0.03 log units) below, within the range that was stated.
By their numbers in this assay, from the lowest: compounds 1, 3 and 2 (each within the scatter of the next, the first and the last beyond it).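

Within the data shown here, with compound 3 in hand, the iodo group can for the first time be read on its own in this assay: with the chloro group held in place, swapping hydrogen for iodo on the phenyl ring gives a 1.8-fold lower number from compound 2 to compound 3 (0.25 log units; within the scatter). The same compound also isolates the chloro group, since with the 4-iodophenyl group held in place, chloro in place of hydrogen gives a 1.3-fold higher number from compound 1 to compound 3 (0.10 log units; within the scatter). Both single changes therefore stay within the scatter, so neither can be said to shift the number on its own in this assay, and no information is available to explain either step.

From the compounds shown here alone, what remains open is whether a different group in that same place, such as an amine, a methoxy group or a carboxylic acid, would move the number beyond the scatter, where iodo does not. Going by these compounds, it is also open how the iodo step would read on a core without the chloro group, and whether the chloro step would hold with a plain phenyl in place of the 4-iodophenyl group.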